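A few compounds are considered here, and "the series" means these few. Any claim that something is new, unique, unknown or untested is made for them only; others in the source may bear on it.

Measured so far in an ADME assay on microsomes from liver (Mus musculus) for metabolic stability, read by LC-MS, with NADPH named in the record, with a stated time of 60 min, tested at 1 uM, in the absence of a further agent; a higher number here means that more of the compound is left, a lower number that less of the compound is left:
- compound 1 `CC(=O)N[C@@H]1CCN(c2cc(C)nn3c(-c4ccc(C(F)(F)F)cc4)c(C)nc23)C1`: > 95%
- compound 2 `COc1ccc(-c2c(C)nc3c(N4CC[C@@H](NC(=O)C(F)(F)F)C4)cc(C)nn23)cc1OC`: > 95%

Compound 1 `CC(=O)N[C@@H]1CCN(c2cc(C)nn3c(-c4ccc(C(F)(F)F)cc4)c(C)nc23)C1` gives > 95% in this assay, which is a limit of the assay rather than a number. Compound 2 `COc1ccc(-c2c(C)nc3c(N4CC[C@@H](NC(=O)C(F)(F)F)C4)cc(C)nn23)cc1OC` likewise gives > 95% in this assay, again a limit and not a number. Among the measured compounds shown here, compound 2 therefore stands at the limit of > 95% in this assay, at which 2 of the 2 values shown sit, so its true position is known only as being on or beyond that edge, and no step between measured compounds is available to guide the next change.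

Compound 3 `COc1ccc(-c2c(C)nc3c(N4CC[C@@H](NS(=O)(=O)c5ccc(C(C)=O)cc5)C4)cc(C)nn23)cc1OC` differs from compound 2 by (4-acetylphenyl)sulfonyl in place of (trifluoromethyl)carbonyl on an amine nitrogen. Because compound 2 sits at the limit of > 95% in this assay, at which 2 of the 2 values shown sit, any step downward can only be seen once the value falls below that limit. A modest downward step is expected here, beyond the scatter but not large. The step from compound 2 to compound 3 is estimated as a number at least 17 percentage points lower from compound 2 to compound 3 (beyond the scatter). Compound 3 is thus expected to give about 78% in this assay, within a range from 45% to 95%.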

Compound 3, percent of the compound remaining: > 95%
Compound 3 was reported as a limit (the forecaster's own chance of this, stated with the estimate: 30%); middle value at least 17 percentage points away from the limit.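

In this assay compound 3 gives > 95%, a limit and not a number, so no step between compound 2 and compound 3 can be read: the limit of > 95% in this assay, at which 3 of the 3 values shown sit.

The compounds shown leave open how far each lies beyond that limit, and which change would bring a value into the readable range.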